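The source may report more compounds than this note shows. Statements on the series, on what has been measured and on what is new or still open speak of the compounds shown alone.

Compound 1 `CCOC(=O)c1ccc(Nc2ccnc(SCC(=O)c3ccc([N+](=O)[O-])cc3)n2)cc1`: 27%
Compound 2 `CCOC(=O)c1ccc(Nc2ccnc(SCC(=O)c3ccc(C#N)cc3)n2)cc1`: 26%
Compound 3 `CC(=O)c1cccc(Nc2ccnc(SCC(=O)c3ccc(-c4ccccc4)cc3)n2)c1`: 15%

All three were tested in a functional assay on EKVX cells (Homo sapiens) for inhibition, read by sulforhodamine B assay, with a stated time of 48 h, tested at 10 uM; a lower number here means less inhibition of growth, a higher number more inhibition of growth at the concentration tested. Among them compound 3, at 15%, stands lowest, and its gaps to compound 1 and compound 2 both lie beyond the scatter. Compound 4 `CC(=O)c1cccc(Nc2ccnc(SCC(=O)c3ccc(C(F)(F)F)cc3)n2)c1` has not yet been measured. It departs from compound 3 in one place, with trifluoromethyl in place of phenyl on an aromatic carbon, para to a large group (trifluoromethyl in place of phenyl on an aromatic carbon).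

For the measured compounds named here, only one measured step bears on this change, and only loosely. Cyano in place of nitro on an aromatic carbon gave a number 1 percentage points lower from compound 1 to compound 2 (within the scatter). Going by the values given here, that exchange involves neither group at issue here, and no measured pair shows the loss of a phenyl. Compound 1 and compound 2 also differ from compound 3 elsewhere in the molecule, so their higher values cannot be assigned to the phenyl alone. Still, neither carries a phenyl at that carbon, and compound 2 stands at 26%, so a small rise is expected, no larger than the scatter. The expected step is a number 5 percentage points higher from compound 3 to compound 4 (within the scatter). In this assay, the estimate for compound 4 is 20%, with an expected range from 8% to 33%.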

Compound 4, percent growth inhibition at one concentration: 28%
Beside the measured number, compound 4's estimate is 8 percentage points below it, within the range that was stated.
By their numbers in this assay, from the lowest: compound 3; then compounds 2, 1 and 4 (each within the scatter of the next).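

In this assay, trifluoromethyl in place of phenyl on an aromatic carbon, para to a large group, gave a number 13 percentage points higher from compound 3 to compound 4 (beyond the scatter). This is the first step among these compounds to lie beyond the scatter, and it shows that, on the core of compound 3, the group at this carbon can alter the growth inhibition read at the concentration tested, whereas the only earlier step, in a different pair of compounds, was a number 1 percentage points lower from compound 1 to compound 2 (within the scatter). No measurement shown here explains the rise.

With a single replacement for phenyl, the compounds shown leave open whether the higher number belongs to trifluoromethyl itself or would also follow from another group at this carbon, such as a methyl, a methoxy group, an amine or a carboxylic acid, or from plain hydrogen there. They also leave open whether the same exchange would give a step of similar size on the core of compound 1, where the other part of the molecule differs from that of compound 3.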